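Swapping the Amine Tail for a Seven-Membered Ring

A few compounds are considered here, and "the series" means these few. Any claim that something is new, unique, unknown or untested is made for them only; others in the source may bear on it.

Compound 1 `CC(C)N(CCN(C(=O)Nc1ccc(F)c(Cl)c1)C1CC[C@]2(c3cccc(C#N)c3)CC2C1)C(C)C` is a urea built on a shared core that carries a nitrile-bearing aryl group, with a diisopropylamino tail on the chain leading from the urea nitrogen. In a functional assay for antagonist activity at melanin-concentrating hormone receptor 1 (Homo sapiens) (a higher number here means a weaker inhibitor, a lower number a stronger inhibitor), compound 1 gives 4.98 nM. Among the three measured compounds it holds the second highest number: compound 2 `CC(C)N(CCN(C(=O)Nc1cccc(Br)c1)C1CC[C@]2(c3cccc(C#N)c3)CC2C1)C(C)C` gives 5.7 nM, and the step of a 1.1-fold higher number from compound 1 to compound 2 (0.06 log units; within the scatter) is within the scatter, while compound 3 `CC(C)N(CCN(C(=O)Nc1cccc(F)c1)C1CC[C@]2(c3cccc(C#N)c3)CC2C1)C(C)C` gives 2.1 nM, and the step of a 2.4-fold lower number from compound 1 to compound 3 (0.38 log units; beyond the scatter) is a modest gain. The step of a 2.7-fold lower number from compound 2 to compound 3 (0.43 log units; beyond the scatter) points the same way.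

Compound 4 `N#Cc1cccc([C@]23CCC(N(CCN4C=CC=CC=C4)C(=O)Nc4ccc(F)c(Cl)c4)CC2C3)c1` differs from compound 1 in one place: a group of 7 heavy atoms (6 carbon, 1 nitrogen; one seven-membered non-aromatic ring with 1 hetero atom) in place of a group of 7 heavy atoms (6 carbon, 1 nitrogen; no ring), on a saturated chain carbon, two bonds along the chain from an amide-type nitrogen. Every measured step changes the aryl group on the urea nitrogen and leaves the tail untouched, so none of them bears on this change. Going by the values given here, the only anchor is the value of compound 1 4.98 nM, and the expectation that follows rests on it with a wide margin.

For compound 4 in this assay the estimate is 10 nM, between 2 nM and 60 nM. Among the compounds with values here, this estimate corresponds to a step of a 2.0-fold higher number from compound 1 to compound 4 (0.30 log units; within the scatter), which is expected to stay close to the scatter, with no measured step to point the direction.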

Compound 4, inhibition constant: 15 nM
For compound 4 the middle estimate is 1.5-fold (0.18 log units) below the measured one; the measured number falls inside the stated range.
By their numbers in this assay, from the lowest: compound 3; then compounds 1 and 2 (each within the scatter of the next); then compound 4.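

Going by these compounds alone, the earlier compounds differ only in the aryl group on the urea nitrogen, so this is the first reading of a change at the other end of the molecule, on a saturated chain carbon, two bonds along the chain from an amide-type nitrogen. In this assay, putting the seven-membered ring in place of diisopropylamino gives a modest weakening (a 3.0-fold higher number from compound 1 to compound 4 (0.48 log units; beyond the scatter)), even though both groups have 7 heavy atoms, 0 hydrogen-bond donors, 1 hydrogen-bond acceptor and no net charge, so those counts alone do not set the value at this position. Nothing measured here explains the weakening.

The compounds shown leave open whether the ring itself or its 3 double bonds account for the difference, a question that a saturated seven-membered azepane ring or a smaller piperidine ring on the same chain would address. They also leave open whether the seven-membered ring would have the same effect alongside the 3-fluorophenyl group of compound 3 or the 3-bromophenyl group of compound 2.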